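Compound 3: hydrogen in place of trifluoromethyl

The compounds below may be only part of what the source reports. "The series", "measured", "known", "first", "only" and "open" are said of these compounds alone.

In a physicochemical assay for solubility, using the shake flask method, with a stated time of 24 h, at pH 6.8 (a lower number here means a less soluble compound, a higher number a more soluble compound), compound 1 (`O=c1ncn(Cc2c(F)cc(F)cc2F)c2ccc(Oc3cccnc3C(F)(F)F)cc12`) gives 2.7 ug/mL. Compound 2 (`O=c1ncn(Cc2c(F)cc(F)cc2F)c2ccc(Oc3ccccc3C(F)(F)F)cc12`) gives < 0.1 ug/mL, which is a limit and not a number. Compound 2 therefore stands at the limit of < 0.1 ug/mL in this assay, at which 1 of the 2 values shown sits.

Compound 3 (`O=c1ncn(Cc2c(F)cc(F)cc2F)c2ccc(Oc3ccccc3)cc12`) has hydrogen in place of trifluoromethyl on an aromatic carbon. Among the measured compounds shown here, one measured step bears on this change, and only indirectly: an at least 27-fold lower number from compound 1 to compound 2 (1.43 log units; beyond the scatter), with 2-(trifluoromethyl)phenyl in place of 2-(trifluoromethyl)pyridin-3-yl. That step is large, but it is a different change and leaves trifluoromethyl in place, so it shows only that the read-out can move widely with changes to this group. A moderate upward move is expected in this assay, smaller than that step, and the expected step is an at least 5.0-fold higher number from compound 2 to compound 3 (0.69 log units; beyond the scatter). For compound 3 the estimated value is 0.5 ug/mL, with an expected range of 0.1 ug/mL to 3 ug/mL.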

Compound 3, solubility: 4.6 ug/mL
The estimate for compound 3 lay 9.2-fold (0.96 log units) below the measured number; measured number above the stated range.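

In this assay, hydrogen in place of trifluoromethyl on the aromatic carbon gives an at least 46-fold higher number from compound 2 to compound 3 (1.66 log units; beyond the scatter), so the phenyl ring alone does not account for the low reading; among these three compounds, it appears only with trifluoromethyl on the ring of carbon only. The other new step, a 1.7-fold higher number from compound 1 to compound 3 (0.23 log units; within the scatter), lies within the scatter, so phenyl and 2-(trifluoromethyl)pyridin-3-yl on this oxygen cannot be told apart here. Compound 2 is held at a limit and not a number, so the full size of its steps stays unknown: the limit of < 0.1 ug/mL in this assay, at which 1 of the 3 values shown sits.

Open, from the compounds shown here alone, is whether a pyridin-3-yl ring without trifluoromethyl would read like phenyl. Also open, going by these compounds, is what methyl, a chlorine atom or an amine would do on this aromatic carbon.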